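Removing one bromo: from compound 2 to compound 3

The source may report more compounds than this note shows. Statements on the series, on what has been measured and on what is new or still open speak of the compounds shown alone.

Compound 1 `Cn1c(-c2cn(C)c3cc(Br)ccc23)cnc1-c1cn(C)c2ccccc12`: 800 nM
Compound 2 `Cn1c(-c2cn(C)c3cc(Br)ccc23)cnc1-c1cn(C)c2cc(Br)ccc12`: 800 nM

Level with compound 1 in a functional assay on P388 cells (Mus musculus) for cytotoxicity (on this read-out higher numbers stand for weaker inhibition and lower numbers for stronger inhibition), compound 2 gives 800 nM. Compound 3 `Cn1c(-c2cn(C)c3ccccc23)cnc1-c1cn(C)c2cc(Br)ccc12` differs from it as follows: hydrogen in place of bromo on an aromatic carbon. For the measured compounds named here, the one measured step of this kind is the same exchange in reverse, with no change at the digits printed from compound 1 to compound 2 (within the scatter). On that single step, no shift beyond the scatter is expected in this assay. The expected step is no change at the digits printed from compound 2 to compound 3 (within the scatter). For compound 3 the estimated value is 800 nM, with an expected range of 350 nM to 1800 nM.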

Compound 3, half-maximal inhibitory concentration: 800 nM
Compound 3: the middle estimate sits on the measured number at the digits printed; measured number inside the range.
By their numbers in this assay, from the lowest: compounds 1, 2 and 3 (each within the scatter of the next).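

The second bromo of compound 2, on an aromatic carbon of the other fused system, can also give way to hydrogen: in this assay this exchange gives no change at the digits printed from compound 2 to compound 3 (within the scatter) and so the earlier step is not peculiar to one of the two places. Bromo is therefore dispensable at this position in this read-out, at least while the other bromo stays in place. No available data explain this flat response. Going by these compounds, what remains open is whether the core with hydrogen at both places holds the same level, and whether an amine or a carboxylic acid on this aromatic carbon would shift the value.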